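The source may report more compounds than this note shows. Statements on the series, on what has been measured and on what is new or still open speak of the compounds shown alone.

Measured so far in a functional assay on U-87MG ATCC cells (Homo sapiens) for cytotoxicity, read by MTT assay, with a stated time of 72 h; on this read-out lower numbers stand for stronger inhibition and higher numbers for weaker inhibition:

compound 1 `COc1cc2c(Oc3ccc(NC(=O)c4cc(-c5ccc(F)cc5)ccn4)cc3F)ccnc2cc1OCCCN1CCCCC1`: 12500 nM
compound 2 `COc1cc2c(Oc3ccc(NC(=O)c4cc(-c5ccccc5)ccn4)cc3F)ccnc2cc1OCCCN1CCCC1`: 1010 nM
compound 3 `COc1cc2c(Oc3ccc(NC(=O)c4cc(-c5ccc(F)cc5)ccn4)cc3F)ccnc2cc1OCCCN1CCCC1`: 1780 nM

Compound 2 and compound 3 sit close together: the step of a 1.8-fold higher number from compound 2 to compound 3 (0.25 log units; within the scatter) is within the scatter and belongs to the change (hydrogen in place of fluoro on an aromatic carbon). Among the measured compounds shown here, the one step that stands out is a 7.0-fold higher number from compound 3 to compound 1 (0.85 log units; beyond the scatter), which comes with the change (piperidin-1-yl in place of pyrrolidin-1-yl on a saturated chain carbon, three bonds along the chain from an oxygen on an aromatic ring).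

Compound 4 `COc1cc2c(Oc3ccc(NC(=O)c4cc(-c5ccccc5)ccn4)cc3F)ccnc2cc1OCCCN1CCCCC1` has not yet been measured in this assay. Against compound 2 it carries the change (piperidin-1-yl in place of pyrrolidin-1-yl on a saturated chain carbon, three bonds along the chain from an oxygen on an aromatic ring), the same change already seen from compound 3 to compound 1, at the same place, on a core that differs from the core of compound 3 only by hydrogen in place of fluoro on an aromatic carbon. With a single measured instance of this change, the step from compound 2 to compound 4 is expected to be of about the same size, a 6.9-fold higher number from compound 2 to compound 4 (0.84 log units; beyond the scatter), resting on a 7.0-fold higher number from compound 3 to compound 1 (0.85 log units; beyond the scatter). For the measured compounds named here, for compound 4 the estimate in this assay is 7000 nM, with the likely span from 2500 nM to 20000 nM; the span is wide since the step of a 7.0-fold higher number from compound 3 to compound 1 (0.85 log units; beyond the scatter) is the only measured instance of this change.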

Compound 4, half-maximal inhibitory concentration: 790 nM
Compound 4: middle estimate off by 8.9-fold (0.95 log units), on the high side; the whole stated range lies above it.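

In this assay, piperidin-1-yl in place of pyrrolidin-1-yl gives a 1.3-fold lower number from compound 2 to compound 4 (0.11 log units; within the scatter), which lies within the scatter, so the larger step seen on the core of compound 3 does not carry over to the core of compound 2: the same change on two cores in this assay, a 7.0-fold higher number (0.85 log units; beyond the scatter) from compound 3 to compound 1 and a 1.3-fold lower number (0.11 log units; within the scatter) from compound 2 to compound 4, 9.0-fold (0.95 log units) apart, beyond the scatter of two such steps Read the other way, hydrogen in place of fluoro on an aromatic carbon gives a 16-fold lower number from compound 1 to compound 4 (1.20 log units; beyond the scatter) with piperidin-1-yl on the chain, so the two changes do not add independently: the same change on two cores in this assay, a 1.8-fold higher number (0.25 log units; within the scatter) from compound 2 to compound 3 and a 16-fold higher number (1.20 log units; beyond the scatter) from compound 4 to compound 1, 9.0-fold (0.95 log units) apart, beyond the scatter of two such steps These four compounds show that the size of each step depends on the other change, but they do not show why, and two cores cannot predict the step on a further core.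

From the compounds shown here alone, it remains open whether the same dependence would appear with chloro or methoxy in place of fluoro, or with morpholin-4-yl or azepan-1-yl on the chain. Also open, going by these compounds, is whether it would persist with a 2-(piperidin-1-yl)ethyl chain.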